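Notes on compound 4: cyclopentylamino in place of propoxy

The compounds below may be only part of what the source reports. "The series", "measured", "known", "first", "only" and "open" are said of these compounds alone.

Compound 1 `Cc1cccnc1-c1ccc(C(=O)Nc2ccc(C(C)(C)C)cc2)cc1` gives 11 nM in a functional assay for antagonist activity at transient receptor potential cation channel subfamily V member 1 (Homo sapiens), read by FLIPR; a higher number here means a weaker inhibitor, a lower number a stronger inhibitor. Compound 2 `CC(C)(C)c1ccc(NC(=O)c2ccc(-c3ncccc3F)cc2)cc1` gives 3 nM in this assay, and compound 3 `CCCOc1cccnc1-c1ccc(C(=O)Nc2ccc(C(C)(C)C)cc2)cc1` gives 62 nM, the highest of the three numbers, separated from the other two by steps beyond the scatter. Compound 4 `CC(C)(C)c1ccc(NC(=O)c2ccc(-c3ncccc3NC3CCCC3)cc2)cc1` differs from compound 3 by cyclopentylamino in place of propoxy on an aromatic carbon. For the measured compounds named here, the steps that bear on this change are the two that led into compound 3 at the same position: a 5.6-fold higher number from compound 1 to compound 3 (0.75 log units; beyond the scatter) and a 21-fold higher number from compound 2 to compound 3 (1.32 log units; beyond the scatter). Both show higher numbers when a larger group sits at this position, and cyclopentylamino is the largest group tried here so far. On that basis the expected step is a 2.4-fold higher number from compound 3 to compound 4 (0.38 log units; beyond the scatter), a further rise or at best no change beyond the scatter. Compound 4 is estimated at 150 nM, with a range of 40 nM to 600 nM.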

Compound 4, half-maximal inhibitory concentration: 190 nM
The estimate for compound 4 lay 1.3-fold (0.10 log units) below the measured number, within the range that was stated.
By their numbers in this assay, from the lowest: compound 2; then compound 1; then compound 3; then compound 4.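

Cyclopentylamino brings a ring and a hydrogen-bond donor to this position for the first time, and the number still rises, with a 3.1-fold higher number from compound 3 to compound 4 (0.49 log units; beyond the scatter) as the step. For the compounds shown here, measured against the two smaller groups, the change gives a 63-fold higher number from compound 2 to compound 4 (1.80 log units; beyond the scatter) and a 17-fold higher number from compound 1 to compound 4 (1.24 log units; beyond the scatter), so fluoro, methyl, propoxy and cyclopentylamino now form an order with no compound among the four going against it. Nothing available explains this rise.

Open, as far as these compounds go, is whether the ring or the nitrogen-hydrogen matters more: cyclopentyloxy and a plain amine would separate the two.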